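This account rests on a few compounds, and the source may have more. Where it says the series, first, only, none or still open, it means among the compounds named here.

The series shares one core carrying a methylsulfonyl-substituted benzyl group and an imine-linked aryl substituent. Compound 1 `CS(=O)(=O)c1ccc(Cc2n[nH]c(=S)n2/N=C/c2ccc(-c3ccccc3)cc2)cc1` bears a biphenyl group at that position, and in a functional assay on HeLa cells (Homo sapiens) for cytotoxicity, read by MTT assay, with a stated time of 48 h, tested at 25 uM (on this read-out higher numbers stand for a stronger effect at the one concentration tested and lower numbers for a weaker effect), compound 1 gives 37.3%. Compound 2 `CS(=O)(=O)c1ccc(Cc2n[nH]c(=S)n2/N=C/c2ccc(F)cc2)cc1` carries a 4-fluorophenyl group instead, and in this assay compound 2 gives "not active" (no number reported): no number was reported for compound 2, it was simply recorded as showing no measurable effect, so compound 2 stands at the bottom of the series without a value that can be placed on the scale.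

Compound 3 `CS(=O)(=O)c1ccc(Cc2n[nH]c(=S)n2/N=C/c2cccnc2)cc1` is the next compound to be examined. It differs from compound 2 in one place (pyridin-3-yl in place of 4-fluorophenyl on a carbon with a double bond to nitrogen). For the measured compounds named here, no step between measured compounds of this type is available, so the expectation for compound 3 rests only on compound 2 and compound 1. Since compound 2 gives "not active" (no number reported), any change in this assay from compound 2 to compound 3 is expected to be small, most likely none beyond the scatter, with a real possibility that compound 3 is again reported without a number. Compound 3 is estimated to give 8% in this assay, expected between 0% and 25%.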

Compound 3, a percentage reported as activity, at one concentration (the size of the read-out at that concentration, not a potency): 19.4%
Compound 3: the middle estimate sits 11.4 percentage points below what was measured; measured number inside the range.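

For the compounds shown here, compound 2 is recorded without a number, so no step to compound 3, which gives 19.4%, can be read. The compounds shown leave open how large the effect of exchanging 4-fluorophenyl for pyridin-3-yl is on this read-out. No further data here bear on the result.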